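Replacing 1H-pyrrol-2-yl with Furan-3-yl in a Growth Inhibitor

The source may hold more compounds than are shown below. What is called first, only, known or untested is meant among the compounds shown, and "the series" means these compounds.

Three compounds have numbers in a functional assay on BE(2)-C cells (Homo sapiens) for inhibition, read by MTT assay, with a stated time of 72 h; a lower number here means a stronger inhibitor of growth, a higher number a weaker inhibitor of growth. Compound 1 `N#C/C(=C\c1c(F)c(F)c(F)c(F)c1F)C(=O)c1ccc[nH]1` gives 14000 nM. Compound 2 `N#C/C(=C\c1ccc([N+](=O)[O-])cc1)C(=O)c1c[nH]c2ccccc12` gives 40000 nM. Compound 3 `COc1ccc(CNC(=O)/C(C#N)=C/c2ccc[nH]2)cc1` gives 47000 nM, the highest of the three, though its gap to compound 2 lies within the scatter; only its gap to compound 1 lies beyond it.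

Compound 4 `COc1ccc(CNC(=O)/C(C#N)=C/c2ccoc2)cc1` differs from compound 3 in one place: furan-3-yl in place of 1H-pyrrol-2-yl on a double-bonded chain carbon bound to a double-bonded chain carbon. For the measured compounds named here, no measured pair shows what this kind of swap does, so no direction can be read from the data. The step of a 1.1-fold higher number from compound 3 to compound 4 (0.03 log units; within the scatter) is therefore expected to stay within the scatter. Compound 4 is expected to give about 50000 nM, with a range from 18000 nM to 140000 nM.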

Compound 4, concentration for 50% growth inhibition: 7000 nM
The estimate for compound 4 lay 7.1-fold (0.85 log units) above the measured number; the measured number lies below the stated range.
By their numbers in this assay, from the lowest: compounds 4 and 1 (each within the scatter of the next); then compounds 2 and 3 (each within the scatter of the next).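

In this assay the ring at this place matters: furan-3-yl in place of 1H-pyrrol-2-yl gives a 6.7-fold lower number from compound 3 to compound 4 (0.83 log units; beyond the scatter) and so turns the weakest-looking side of the series into its stronger side. The swap changes several things at once, as ring nitrogen becomes oxygen, the hydrogen-bond donor is lost, and the attachment goes from 2-yl to 3-yl. Nothing available separates these changes or explains the step.

On these data alone, whether furan-2-yl or thiophen-3-yl at the same place would do as well remains open. So does whether this swap has the same effect on another core.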